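A few compounds are considered here, and "the series" means these few. Any claim that something is new, unique, unknown or untested is made for them only; others in the source may bear on it.

- Compound 1 `Cc1c2c(n3c1CCCNC[C@H](C)Nc1cc-3ccc1C(N)=O)CC(C)(C)CC2=O`: > 0.5 h
- Compound 2 `CC(=O)N1CCc2c(C)c3c(n2-c2ccc(C(N)=O)c(c2)N[C@@H](C)[C@H](C)C1)CC(C)(C)CC3=O`: 0.333 h

For the measured compounds named here, in an in vitro ADME assay on microsomes (Rattus norvegicus) for metabolic stability (on this read-out lower numbers stand for a shorter-lived compound and higher numbers for a longer-lived compound), compound 2 gives 0.333 h, the only exact number so far. Compound 1 gives > 0.5 h, which is a limit of the assay and not a number.

Compound 3 `Cc1c2c(n3c1CCN(C(=O)CN)C[C@@H](C)[C@H](C)Nc1cc-3ccc1C(N)=O)CC(C)(C)CC2=O` differs from compound 2 by one change, (amino in place of hydrogen on a saturated chain carbon bound to a carbonyl carbon), which turns acetyl into (aminomethyl)carbonyl. Going by the values given here, no measured pair of compounds shows what this change does, so the expectation is cautious. The expected step of a 1.1-fold lower number from compound 2 to compound 3 (0.05 log units; within the scatter) in this assay is small, stays within the usual scatter and has no clear direction. For compound 3 the estimated value is 0.3 h, with an expected range of 0.12 h to 0.7 h.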

Compound 3, half-life: > 0.5 h
Compound 3: a limit, no number (the forecaster's own chance of this, stated with the estimate: 15%); middle value at least 1.6-fold (0.22 log units) away from the limit.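

Amino in place of hydrogen on a saturated chain carbon bound to a carbonyl carbon now has a measured effect: in this assay the change gives an at least 1.5-fold higher number from compound 2 to compound 3 (0.17 log units; that floor lies within the scatter) and so does not shorten the half-life. For compound 3, > 0.5 h is a limit of the assay and not a number. The true size of the step stays hidden because the read-out stops there: the limit of > 0.5 h in this assay, at which 2 of the 3 values shown sit.

Still open, as far as these compounds go, is whether a longer chain ending in an amine, or a carboxylic acid in place of the amino group, would behave the same way at this position.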